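Adding a methoxy to compound 3

A few compounds are considered here, and "the series" means these few. Any claim that something is new, unique, unknown or untested is made for them only; others in the source may bear on it.

In a functional assay on K562 cells (Homo sapiens) for antiproliferative activity, read by MTT assay, with a stated time of 48 h (a lower number here means a stronger inhibitor of growth, a higher number a weaker inhibitor of growth), compound 3 `COc1ccc(Cn2cnc3c(Cl)nc(Cl)nc32)cc1OC` gives 7000 nM, the lowest number in this small set. Compound 1 `COc1ccc(N(C)c2nc(Cl)nc3c2ncn3Cc2cc(OC)c(OC)c(OC)c2)cc1` gives the higher 41000 nM. Compound 2 `COc1ccc(Cn2cnc3c(Cl)ncnc32)cc1OC` gives > 50000 nM, which is a limit of the assay and not a number.

Compound 4 `COc1cc(Cn2cnc3c(Cl)nc(Cl)nc32)cc(OC)c1OC` differs from compound 3 by methoxy in place of hydrogen on an aromatic carbon. Within the data shown here, the one measured step, an at least 7.1-fold lower number from compound 2 to compound 3 (0.85 log units; beyond the scatter), involves chloro and not methoxy, so it offers no direct guide to this change. No step beyond the scatter is therefore expected in this assay. The expected step is a 1.1-fold higher number from compound 3 to compound 4 (0.06 log units; within the scatter). For compound 4 the estimated value is 8000 nM, within an expected range of 2500 nM to 30000 nM.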

Compound 4, concentration for 50% growth inhibition: 4300 nM
For compound 4 the middle estimate is 1.9-fold (0.27 log units) above the measured one; the measured number falls inside the stated range.
By their numbers in this assay, from the lowest: compounds 4 and 3 (each within the scatter of the next); then compound 1. At a limit, above all of these: compound 2.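

In this assay methoxy in place of hydrogen, ortho to a methoxy group, gives a 1.6-fold lower number from compound 3 to compound 4 (0.21 log units; within the scatter) and so this position takes the extra group without a measurable change. Chloro in place of (4-methoxyphenyl)(methyl)amino on an aromatic carbon gives a 9.5-fold lower number from compound 1 to compound 4 (0.98 log units; beyond the scatter) and so that other place on the core moves the number further than this methoxy does. No measurement shown explains either step.

From the compounds shown here alone, whether an amine, a hydroxyl or a longer chain would be accepted at this position stays open. So does whether a group larger than methoxy would move the number beyond the scatter.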